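Naphthyl-pyridine series: chain variation and CDK8/Cyclin C inhibition

This account rests on a few compounds, and the source may have more. Where it says the series, first, only, none or still open, it means among the compounds named here.

Measured so far:
compound 1 `O=C(O)CCc1ccncc1-c1ccc2ccccc2c1`: 101%
compound 2 `NNC(=O)CCc1ccncc1-c1ccc2ccccc2c1`: 102%
compound 3 `NNC(=O)COc1ccncc1-c1ccc2ccccc2c1`: 19%

All three share one core and differ only in the side chain on the pyridine. In an assay on a protein complex for inhibition of CDK8/Cyclin C (Homo sapiens), with a stated time of 1 h, tested at 10 uM (a lower number here means less inhibition, a higher number more inhibition at the concentration tested (going by the name of the read-out)), compound 1 gives 101% and compound 2 gives 102%; the step of a number 1 percentage points higher from compound 1 to compound 2 (within the scatter) shows that exchanging hydroxy for aminoamino at the carbonyl carbon changes nothing measurable. Compound 3 stands lowest of the three, with 19%; the steps of a number 82 percentage points lower from compound 1 to compound 3 (beyond the scatter) and a number 83 percentage points lower from compound 2 to compound 3 (beyond the scatter) are both large, and in each case the change is to a chain carrying an oxygen on the aromatic carbon.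

Compound 4 `CN(C)C(=O)/C=C/c1ccncc1-c1ccc2ccccc2c1` is not yet measured. It differs from compound 3 by 2-(dimethylcarbamoyl)ethenyl in place of (aminocarbamoyl)methoxy on an aromatic carbon. The group that enters is closer in kind to the 2-(aminocarbamoyl)ethyl chain of compound 2 than to the (aminocarbamoyl)methoxy chain of compound 3: the oxygen on the aromatic carbon is gone and the carbonyl again sits at the end of a two-carbon chain. The two large downward steps a number 82 percentage points lower from compound 1 to compound 3 (beyond the scatter) and a number 83 percentage points lower from compound 2 to compound 3 (beyond the scatter) are the ones that bear here, read in reverse; the small step of a number 1 percentage points higher from compound 1 to compound 2 (within the scatter) suggests the end of the chain matters less than the link to the ring. A large rise is therefore expected, a number 61 percentage points higher from compound 3 to compound 4 (beyond the scatter), with some uncertainty since neither a double bond in the chain nor a dimethylamide has been measured. Compound 4 is estimated at 80% in this assay, within 45% to 105%.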

Compound 4, a percentage reported as inhibition, at one concentration (the size of the read-out at that concentration, not a potency): 100%
Estimate against measurement, compound 4: 20 percentage points below, within the range that was stated.
By their numbers in this assay, from the lowest: compound 3; then compounds 4, 1 and 2 (each within the scatter of the next).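

In this assay, the steps of a number 2 percentage points lower from compound 2 to compound 4 (within the scatter) and a number 1 percentage points lower from compound 1 to compound 4 (within the scatter) show that this position, on an aromatic carbon opposite the ring nitrogen, accepts a chain with 0 hydrogen-bond donors and 2 double bonds outside aromatic rings without a measurable change. Within the data shown here, the step of a number 81 percentage points higher from compound 3 to compound 4 (beyond the scatter) leaves compound 3, the only one of the four with oxygen on the aromatic carbon, as the only low compound, and no compound goes against this, although that step changes both the link and the chain end. No independent evidence explains the difference between these chains.

Still open, going by these compounds, is whether the ring-bound oxygen alone accounts for the low number, a question that a (dimethylcarbamoyl)methoxy chain would address. A longer chain or an amine at the chain end also remains untested in the compounds shown here.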